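Tetrahydropyranyl Alkene Chain in Place of Benzylamine Tail

This account rests on a few compounds, and the source may have more. Where it says the series, first, only, none or still open, it means among the compounds named here.

Measured compounds:
- compound 1, `c1ccc2c(c1)CN[C@@H](CN(CCCCNCc1ccncc1)[C@H]1CCCc3cccnc31)C2`; in a functional assay on cells for agonist activity at C-X-C chemokine receptor type 4 (Homo sapiens), read by fluorescence and calcium flux, with a stated time of 90 s (on this read-out lower numbers stand for an effect already at smaller amounts and higher numbers for an effect only at larger amounts of compound), compound 1 reaches only the assay limit > 30000 nM.
- compound 2, `c1ccc(CNCCCCN(C[C@H]2Cc3ccccc3CN2)[C@H]2CCCc3cccnc32)cc1`; in this assay compound 2 reaches only the assay limit > 30000 nM.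
- compound 3, `c1ccc2c(c1)CN[C@@H](CN(CCCCNC1CCNCC1)[C@H]1CCCc3cccnc31)C2`; in this assay compound 3 reaches only the assay limit > 30000 nM.

Compound 2 therefore stands at the limit, with no number of its own, and the two other values shown are limits as well, so nothing separates it from them. The steps among the measured compounds are a step that the two limits leave unreadable from compound 1 to compound 2, a step that the two limits leave unreadable from compound 1 to compound 3 and a step that the two limits leave unreadable from compound 2 to compound 3, none of which has a readable size, because of the limit of > 30000 nM in this assay, at which 3 of the 3 values shown sit.

Compound 4, `C(=C/CN(C[C@H]1Cc2ccccc2CN1)[C@H]1CCCc2cccnc21)\CNCC1CCOCC1`, differs from compound 2 by a group of 11 heavy atoms (9 carbon, 1 nitrogen, 1 oxygen; one six-membered non-aromatic ring with 1 hetero atom) in place of a group of 11 heavy atoms (10 carbon, 1 nitrogen; one six-membered aromatic ring of carbon only), on a saturated chain carbon bound to an amine nitrogen.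

Going by the values given here, no measured step bears directly on this change; the three limits only show that three different groups on this amine nitrogen all left the compounds without a measurable effect. Compound 4 is expected to behave the same way, and the step that the limit leaves unreadable from compound 2 to compound 4 is expected to be without a readable size. The estimate for compound 4 in this assay is 40000 nM, within a range from 15000 nM to 100000 nM, most likely reported again as a limit.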

Compound 4, half-maximal effective concentration: > 30000 nM
Compound 4: no number, only a limit; the forecaster's own chance of this, stated with the estimate: 85%; the middle value does not contradict the limit.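

In this assay compound 4 gives > 30000 nM as a limit and not a number. Going by these compounds alone, no step from compound 1, compound 2 or compound 3 to compound 4 can be read, because all the values sit at one limit: the limit of > 30000 nM in this assay, at which 4 of the 4 values shown sit. The compounds shown leave open which group on this amine nitrogen, if any, would give a measurable effect.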